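The compounds below may be only part of what the source reports. "The series", "measured", "known", "first", "only" and "open" are said of these compounds alone.

Measured compounds in a functional assay on OVCAR-3 cells (Homo sapiens) for inhibition, read by MTT assay, with a stated time of 24 h; a higher number here means a weaker inhibitor, a lower number a stronger inhibitor:
compound 1 `CC1(C)[C@H]2CC[C@]1(C)N(Cc1cn(-c3ccc(Cl)cc3)nn1)C(=O)C2` gives 160 nM
compound 2 `CC1(C)[C@H]2CC[C@]1(C)N(Cc1cn(-c3ccccc3)nn1)C(=O)C2` gives 50 nM
compound 3 `CC1(C)[C@H]2CC[C@]1(C)N(Cc1cn(-c3cccc(Br)c3)nn1)C(=O)C2` gives 30 nM

Compound 2 stands second highest of the three numbers. Its nearest neighbour is compound 3, with a 1.7-fold lower number from compound 2 to compound 3 (0.22 log units; within the scatter), a step within the scatter; furthest is compound 1, with a 3.2-fold lower number from compound 1 to compound 2 (0.51 log units; beyond the scatter), which lies beyond the scatter. The remaining measured step, a 5.3-fold lower number from compound 1 to compound 3 (0.73 log units; beyond the scatter), also lies beyond the scatter.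

Compound 4 `CC1(C)[C@H]2CC[C@]1(C)N(Cc1cn(-c3cccc(F)c3)nn1)C(=O)C2` is not yet measured. It differs from compound 2 by fluoro in place of hydrogen on an aromatic carbon. The step that bears most directly on it is a 1.7-fold lower number from compound 2 to compound 3 (0.22 log units; within the scatter), where bromo entered at the same place on the six-membered aromatic ring of carbon only, meta to a large group; that step stayed within the scatter. The two steps beyond the scatter, a 3.2-fold lower number from compound 1 to compound 2 (0.51 log units; beyond the scatter) and a 5.3-fold lower number from compound 1 to compound 3 (0.73 log units; beyond the scatter), both start from compound 1 and concern the 4-chlorophenyl, so they do not speak to a change at this place. For the measured compounds named here, with only one measured step at this place, and that one within the scatter, the expectation for compound 4 in this assay is a number close to compound 2, with no step beyond the scatter in either direction. The estimate for compound 4 is 45 nM, with a range from 20 nM to 110 nM. The expected step is a 1.1-fold lower number from compound 2 to compound 4 (0.05 log units; within the scatter), within the scatter.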

Compound 4, half-maximal inhibitory concentration: 430 nM
For compound 4 the middle estimate is 9.6-fold (0.98 log units) below the measured one; the measured number lies above the stated range.
By their numbers in this assay, from the lowest: compounds 3 and 2 (each within the scatter of the next); then compound 1; then compound 4.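

At this place, meta to a large group on the six-membered aromatic ring of carbon only, the entering halogen matters in this assay: fluoro gives an 8.6-fold higher number from compound 2 to compound 4 (0.93 log units; beyond the scatter) for the change from hydrogen and a 14-fold higher number from compound 3 to compound 4 (1.16 log units; beyond the scatter) for the change from bromo, although bromo itself stayed within the scatter of hydrogen. The closeness of compound 2 and compound 3 therefore cannot be read as general tolerance of substitution at this place. The 3-fluorophenyl also falls behind the 4-chlorophenyl, with a 2.7-fold higher number from compound 1 to compound 4 (0.43 log units; beyond the scatter) in this comparison, which leaves compound 4 as the weakest of the four, since its steps to all the others lie beyond the scatter. No measurement at hand accounts for the separation between fluoro and bromo.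

With only hydrogen, bromo and fluoro shown at this place, it stays open whether fluoro or bromo is the exception, and chloro, methyl or methoxy there would help to settle that. Equally open, from the compounds shown here alone, is whether an amine or a carboxylic acid at this place would track compound 4 or compound 3 in the series.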